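Working notes: from carboxy to carbamoyl in compound 3

A few compounds are considered here, and "the series" means these few. Any claim that something is new, unique, unknown or untested is made for them only; others in the source may bear on it.

Measured so far in a functional assay on HeLa cells (Homo sapiens) for cytotoxicity, read by sulforhodamine B assay, with a stated time of 48 h (a lower number here means a stronger inhibitor of growth, a higher number a weaker inhibitor of growth), are two compounds:
- compound 1 `Cc1nn(-c2ccccc2)c(Oc2ccc(-c3nc4cc(C(=O)O)ccc4[nH]3)cc2)c1/C=N/Nc1ccccc1` gives 15000 nM
- compound 2 `Cc1nn(-c2ccccc2)c(Oc2ccc(-c3nc4cc(C(=O)O)ccc4[nH]3)cc2)c1/C=N/NC(N)=S` gives 22700 nM

These two numbers do not separate the compounds. Among the compounds with values here, the only measured step is a 1.5-fold higher number from compound 1 to compound 2 (0.18 log units; within the scatter), so compound 2 stands level with its single neighbour and no ranking can be drawn.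

The next structure is compound 3 `Cc1nn(-c2ccccc2)c(Oc2ccc(-c3nc4cc(C(N)=O)ccc4[nH]3)cc2)c1/C=N/NC(N)=S`, and the change is amino in place of hydroxy on a carbonyl carbon. In words, this is amino in place of hydroxy on a carbonyl carbon, or carboxy to carbamoyl.

Within the data shown here, no measured step covers this exchange. Among the measured compounds shown here, the one available step is an exchange on an amine nitrogen, elsewhere in the molecule, so it bears only indirectly. The series has not yet shown any step beyond the scatter, but two compounds are thin evidence, and the range must stay wide.

Starting from compound 2 at 22700 nM, no step beyond the scatter is expected in this assay. The estimated step is a 1.3-fold lower number from compound 2 to compound 3 (0.10 log units; within the scatter) in size. For compound 3 the expected value is 18000 nM, with an estimated range from 7000 nM to 45000 nM.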

Compound 3, concentration for 50% growth inhibition: 14600 nM
Compound 3: the middle estimate sits 1.2-fold (0.09 log units) above what was measured; measured number inside the range.
By their numbers in this assay, from the lowest: compounds 3, 1 and 2 (each within the scatter of the next).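

In this assay, the step at the carbonyl carbon, amino in place of hydroxy, reads a 1.6-fold lower number from compound 2 to compound 3 (0.19 log units; within the scatter), so carboxy to carbamoyl does not separate these two compounds. The earlier compounds offered a single step, on an amine nitrogen, and this result adds a second place on the shared core where the step also stays within the scatter, so neither place has yet shown a step beyond it. No measurement is available that would explain this result.

From the compounds shown here alone, whether another group on this carbonyl carbon, such as a methyl ester or an amide carrying two methyl groups on its nitrogen, would give a step beyond the scatter remains open, as does the behaviour of carbamoyl together with the phenyl group that compound 1 carries on the amine nitrogen. With only these two single-place steps, the series also leaves open how far the other parts of the shared core, such as the phenyl group on the ring nitrogen or the methyl group, matter in this assay.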